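Trimming the Side Chain: Sec-Butyl to Isopropyl

The source may hold more compounds than are shown below. What is called first, only, known or untested is meant among the compounds shown, and "the series" means these compounds.

Measured compounds:
Compound 1, `CC(=O)c1ccc(NC(=O)C(CC(C)C)N(C(=O)c2ccccc2)S(=O)(=O)c2ccc([N+](=O)[O-])cc2)cc1` — 45%
Compound 2, `CCC(C)C(C(=O)Nc1ccc(C(C)=O)cc1)N(C(=O)c1ccccc1)S(=O)(=O)c1ccc([N+](=O)[O-])cc1` — 28.6%

In a functional assay for inhibition, read by spectrophotometry, with a stated time of 20 min, tested at 1 mg/mL (a higher number here means a stronger effect of the compound at the concentration tested, a lower number a weaker effect), compound 2 stands lowest of the two numbers, with compound 1 giving the nearer and higher figure. Compound 3, `CC(=O)c1ccc(NC(=O)C(C(C)C)N(C(=O)c2ccccc2)S(=O)(=O)c2ccc([N+](=O)[O-])cc2)cc1`, differs from compound 2 by hydrogen in place of methyl on a saturated chain carbon, three bonds along the chain from an amide-type nitrogen and a carbonyl carbon. Within the data shown here, the only measured step, a number 16.4 percentage points lower from compound 1 to compound 2 (beyond the scatter), concerns the same chain carbon but alters branching rather than chain length, so it bears on the new change only loosely. Among the measured compounds shown here, no step removes a methyl outright. Compound 3 is therefore expected to sit close to compound 2, with a change of a number 1.6 percentage points lower from compound 2 to compound 3 (within the scatter) that stays within the scatter. Compound 3 is estimated at 27%, ranging from 10% to 48%.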

Compound 3, a percentage reported as inhibition, at one concentration (the size of the read-out at that concentration, not a potency): 29.8%
Compound 3: middle estimate off by 2.8 percentage points, on the low side, and the stated range covers the measured number.
By their numbers in this assay, from the lowest: compounds 2 and 3 (each within the scatter of the next); then compound 1.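

In this assay, the step from sec-butyl to isopropyl, a number 1.2 percentage points higher from compound 2 to compound 3 (within the scatter), shows that this methyl can be removed with no change that stands clear of the scatter. The step from isobutyl to isopropyl, a number 15.2 percentage points lower from compound 1 to compound 3 (beyond the scatter), shows that isobutyl stands apart from both sec-butyl and isopropyl in this small set. No supporting data bear on why these values fall as they do. Going by these compounds, what remains open is how a longer chain, an amine or a carboxylic acid at this position would read out.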